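Removing the Chain Double Bond: Expected Effect on Seizure Protection

This account rests on a few compounds, and the source may have more. Where it says the series, first, only, none or still open, it means among the compounds named here.

Of the compounds shown here, three sharing one core have been measured in a functional assay on the whole organism (strain albino CF-1) with Mus musculus as the target, in the maximal electroshock model, with a stated time of 4 h; a lower number here means that less compound is needed, a higher number that more compound is needed for the effect. Compound 1 `C=CCOc1cccc(/C=N/n2c(-c3ccccc3)nc3ccccc3c2=O)c1` gives 300 mg/kg. Compound 2 `O=c1c2ccccc2nc(-c2ccccc2)n1/N=C/c1cccc(OCc2ccccc2)c1` gives 300 mg/kg. Compound 3 `C=CCCOc1cccc(/C=N/n2c(-c3ccccc3)nc3ccccc3c2=O)c1` gives 100 mg/kg, the lowest of the three numbers. a 3.0-fold lower number from compound 1 to compound 3 (0.48 log units; beyond the scatter) and a 3.0-fold lower number from compound 2 to compound 3 (0.48 log units; beyond the scatter), while no change at the digits printed from compound 1 to compound 2 (within the scatter).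

Compound 4 `CCCCOc1cccc(/C=N/n2c(-c3ccccc3)nc3ccccc3c2=O)c1` is not yet measured. The change is ethyl in place of vinyl on a saturated chain carbon, two bonds along the chain from an oxygen on an aromatic ring. Among the compounds with values here, none of the measured steps replaces a vinyl with an ethyl; each of them alters the carbon bound to the aromatic oxygen. There, allyl in place of vinyl gave a modest step, a 3.0-fold lower number from compound 1 to compound 3 (0.48 log units; beyond the scatter), whereas phenyl in place of vinyl gave no change at the digits printed from compound 1 to compound 2 (within the scatter). The change from compound 3 to compound 4 removes only the double bond outside aromatic rings and keeps the chain otherwise, so a step of no more than modest size in this assay is expected, with no direction favoured. Compound 4 is estimated at 100 mg/kg, with a range from 50 mg/kg to 300 mg/kg, which means an expected step of no change at the digits printed from compound 3 to compound 4 (within the scatter).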

Compound 4, minimum effective dose: 100 mg/kg
Beside the measured number, compound 4's estimate shows no gap at the digits printed; the range from low to high includes it.
By their numbers in this assay, from the lowest: compounds 3 and 4 (each within the scatter of the next); then compounds 1 and 2 (each within the scatter of the next).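

In this assay, the double bond at the end of the chain turns out not to matter at this position: ethyl in place of vinyl gives no change at the digits printed from compound 3 to compound 4 (within the scatter) and so leaves the number where it was. The earlier compounds shown here could not show this, since none of them kept the chain and removed only the double bond. The butyl chain also shows a 3.0-fold lower number from compound 1 to compound 4 (0.48 log units; beyond the scatter) and a 3.0-fold lower number from compound 2 to compound 4 (0.48 log units; beyond the scatter), so among these four compounds the lower numbers go with the but-3-en-1-yl and butyl chains, whether or not a double bond is present, and no measurement here explains why.

On these data alone, whether a longer chain, such as pentyl or hexyl, would lower the number further remains open. So does the effect of placing an amine or a carboxylic acid at the end of the butyl chain.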